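The source may report more compounds than this note shows. Statements on the series, on what has been measured and on what is new or still open speak of the compounds shown alone.

Measured so far:
- compound 1, `C/C(=C\c1cc(-c2ccc(F)cc2)cs1)C(N)=O`: 20800 nM
- compound 2, `C/C(=C\c1nc(-c2ccc(C)cc2)cs1)C(N)=O`: 25000 nM
- compound 3, `C/C(=C\c1cccc(-c2ccc(C)cc2)c1)C(N)=O`: 24800 nM

All three compounds were tested in a functional assay on HeLa cells (Homo sapiens) for cytotoxicity, read by CCK-8 assay, with a stated time of 24 h; on this read-out higher numbers stand for weaker inhibition and lower numbers for stronger inhibition. Compound 1 shows 20800 nM, which is the lowest of the three numbers, but its gaps to compound 2 at 25000 nM and to compound 3 at 24800 nM both lie within the usual scatter of repeated measurements, so the three cannot be told apart on these data. No pair of these compounds differs in only one place, so no single structural step has been measured here.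

The next compound, compound 4, `C/C(=C\c1cc(-c2ccc(S(C)(=O)=O)cc2)cs1)C(N)=O`, keeps the core of compound 1 and changes one group: methylsulfonyl in place of fluoro on an aromatic carbon. Among the compounds with values here, nothing among the measured compounds shows what this kind of exchange does in this assay; the three values so far sit close together, which gives no hint of a sharp response to changes at this position.

In the absence of a measured step, the expectation is for a change from compound 1 to compound 4 of a 1.2-fold higher number from compound 1 to compound 4 (0.08 log units; within the scatter), that is, none beyond the scatter. Compound 4 is therefore estimated at 25000 nM, within a range from 10000 nM to 60000 nM.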

Compound 4, half-maximal inhibitory concentration: > 50000 nM
Compound 4 gave a limit, no number (the forecaster's own chance of this, stated with the estimate: 15%); at least 2.0-fold (0.30 log units) between middle value and limit.
By their numbers in this assay, from the lowest: compounds 1, 3 and 2 (each within the scatter of the next). At a limit, above all of these: compound 4.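

In this assay, within the data shown here, this carbon on the six-membered aromatic ring proves sensitive to what it carries: the three earlier values sat within the scatter of one another and included no single-place step, whereas methylsulfonyl in place of fluoro gives an at least 2.4-fold higher number from compound 1 to compound 4 (0.38 log units; beyond the scatter). Compound 4 gives > 50000 nM, which is a limit of the assay and not a number. The change therefore weakens inhibition by a clear margin, but only the smallest possible size of the step can be read, and its full size remains unknown: the limit of > 50000 nM in this assay, at which 1 of the 4 values shown sits.

This single exchange brings in more heavy atoms and two hydrogen-bond acceptors at once, and it cannot show which of these differences, if either, accounts for the step. Going by these compounds, it also remains open how an amine, a methoxy group or a carboxylic acid at the same carbon would behave on the core of compound 1, and whether any group there could give clearly stronger inhibition than fluoro.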